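Pentafluorophenylsulfonamides: swapping the para substituent on the aniline

The compounds below may be only part of what the source reports. "The series", "measured", "known", "first", "only" and "open" are said of these compounds alone.

The measured compounds are:

compound 1, `O=S(=O)(Nc1ccc2[nH]ccc2c1)c1c(F)c(F)c(F)c(F)c1F`, 35 nM
compound 2, `CN(C)c1ccc(NS(=O)(=O)c2c(F)c(F)c(F)c(F)c2F)cc1`, 525 nM
compound 3, `Cc1ccc(NS(=O)(=O)c2c(F)c(F)c(F)c(F)c2F)cc1C`, 468 nM

All three were tested in a functional assay on PC-3 cells (Homo sapiens) for inhibition; on this read-out lower numbers stand for stronger inhibition of growth and higher numbers for weaker inhibition of growth. Compound 2 gives the highest number of the three, 525 nM. Compound 3, with 468 nM, lies within the usual scatter of compound 2, so the two cannot be told apart on this read-out. Compound 1 stands well away: with 35 nM it sits beyond the scatter, far below compound 2.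

The unmeasured compound 4, `COc1ccc(NS(=O)(=O)c2c(F)c(F)c(F)c(F)c2F)cc1`, differs from compound 2 in one place: methoxy in place of dimethylamino on an aromatic carbon. No measured pair shows this change, so its size in this assay is not known from the data shown.

Since compound 2 and compound 3 carry different groups on the same ring yet give numbers within the scatter of each other, a small para substituent swap of this kind is expected to move this assay little. The step of a 1.2-fold lower number from compound 2 to compound 4 (0.07 log units; within the scatter) is therefore expected to be small and most likely within the scatter, with no clear direction. Compound 4 is estimated at 450 nM, within a range from 150 nM to 1400 nM.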

Compound 4, concentration for 50% growth inhibition: < 10 nM
Compound 4 gave a limit, no number (the forecaster's own chance of this, stated with the estimate: 3%); middle value at least 45-fold (1.65 log units) away from the limit.
By their numbers in this assay, from the lowest: compound 1; then compounds 3 and 2 (each within the scatter of the next). At a limit, below all of these: compound 4.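

In this assay compound 4 gives < 10 nM, which is a limit of the assay and not a number. The earlier compounds shown here held no pair differing in one place, and this first such pair shows that the group on this aromatic carbon, para to a large group, matters greatly: methoxy in place of dimethylamino comes with an at least 52-fold lower number from compound 2 to compound 4 (1.72 log units; beyond the scatter), although neither group carries a ring or a net charge. That step gives only the smallest size the change can have, and its full size cannot be read, because compound 4 sits at the limit: the limit of < 10 nM in this assay, at which 1 of the 4 values shown sits.

The compounds shown leave open which feature of the exchange carries the effect, since a single pair cannot separate the oxygen from the nitrogen or the one methyl from the two; ethoxy, hydroxy, methylamino or a plain amine at this place would each bear on that question. They also leave open whether methoxy would have the same effect on the core of compound 1 or compound 3.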